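Moving the Fluorine Within the Aryl Arm of Compound 3

This account rests on a few compounds, and the source may have more. Where it says the series, first, only, none or still open, it means among the compounds named here.

compound 1 `COc1ccccc1/C=c1\c(=O)[nH]/c(=C/c2cccc(Cl)c2Cl)c(=O)n1C` — 200 nM
compound 2 `C=CCn1c(=O)/c(=C\c2ccc(Cl)c(Cl)c2)[nH]c(=O)/c1=C\c1ccccc1` — "not active" (no number reported)
compound 3 `C=CCn1c(=O)/c(=C\c2cccc(F)c2)[nH]c(=O)/c1=C\c1ccccc1OC` — 13700 nM

Of the compounds shown here, three on a shared core have been measured in a functional assay on MCF7 cells (Homo sapiens) for cytotoxicity, read by CCK-8 assay, with a stated time of 72 h; a lower number here means a stronger inhibitor, a higher number a weaker inhibitor. Compound 1 gives 200 nM. Compound 2 is recorded as "not active" (no number reported), with no number attached. Compound 3 gives 13700 nM, the higher of the two numbers reported; its nearest neighbour is compound 1, whose number is far lower, a gap well beyond the scatter. Within the data shown here, no pair of measured compounds differs in a single place, so no step of any kind has been seen directly.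

Compound 4 `C=CCn1c(=O)/c(=C\c2ccccc2F)[nH]c(=O)/c1=C\c1ccccc1OC` is the next candidate for this assay. It differs from compound 3 in one place: 2-fluorophenyl in place of 3-fluorophenyl on a double-bonded chain carbon bound to an aromatic carbon. Among the measured compounds shown here, nothing among the measured compounds shows what such a change does, so the expectation is a step of no more than the scatter, in no clear direction: for compound 4 the expected step is a 1.1-fold lower number from compound 3 to compound 4 (0.06 log units; within the scatter). Compound 4 is therefore estimated at 12000 nM, within a range from 3500 nM to 40000 nM.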

Compound 4, half-maximal inhibitory concentration: 23000 nM
Compound 4: the middle estimate sits 1.9-fold (0.28 log units) below what was measured; low and high end bracket the measured number.
By their numbers in this assay, from the lowest: compound 1; then compounds 3 and 4 (each within the scatter of the next).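

In this assay, among these compounds, the exchange of 3-fluorophenyl for 2-fluorophenyl on a double-bonded chain carbon bound to an aromatic carbon gives a 1.7-fold higher number from compound 3 to compound 4 (0.23 log units; within the scatter) and so provides the first single-place step in this set. For these two fluorophenyl groups, the numbers cannot be told apart, so the place of the fluorine on the ring shows no readable effect here. Nothing shown bears on why this is so.

From the compounds shown here alone, it remains open whether a phenyl group carrying an amine or a carboxylic acid instead of the fluorine would give a number distinct from those of compound 3 and compound 4. Compound 1 differs from these two in more than one place, so the gap between their values cannot be assigned to any single group.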